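A few compounds are considered here, and "the series" means these few. Any claim that something is new, unique, unknown or untested is made for them only; others in the source may bear on it.

In a functional assay on NCI-H23 cells (Homo sapiens) for cytotoxicity, read by sulforhodamine B assay, with a stated time of 72 h (a lower number here means a stronger inhibitor of growth, a higher number a weaker inhibitor of growth), compound 1 `O=C(Nc1ccccc1C(F)(F)F)C1CCc2ccccc2N1` gives 56800 nM, and compound 3 `COc1ccc(NC(=O)C2CCc3ccccc3N2)cc1` gives 55700 nM. These two values lie within the scatter of each other, so compound 3 stands level with compound 1. Compound 2 `O=C(Nc1ccc(O)cc1)C1CCc2ccccc2N1` gives > 100000 nM, which is a limit of the assay and not a number. The next compound, compound 4 `O=C(Nc1ccccc1)C1CCc2ccccc2N1`, departs from compound 3 by hydrogen in place of methoxy on an aromatic carbon, with hydrogen in place of methoxy on an aromatic carbon, para to a large group. For the measured compounds named here, only one measured step touches that group, namely an at least 1.7-fold lower number from compound 2 to compound 3 (0.25 log units; that floor lies within the scatter). It replaces hydrogen with methyl on the oxygen of the group, so it bears on the new change only loosely, and its size is a floor set by a limit. On that evidence, no step beyond the scatter is expected in this assay. The expected change is a 1.1-fold higher number from compound 3 to compound 4 (0.03 log units; within the scatter). For compound 4 the estimated value is 60000 nM, with an expected range of 25000 nM to 100000 nM.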

Compound 4, concentration for 50% growth inhibition: 97100 nM
Compound 4: the middle estimate sits 1.6-fold (0.21 log units) below what was measured; low and high end bracket the measured number.
By their numbers in this assay, from the lowest: compounds 3, 1 and 4 (each within the scatter of the next). At a limit, above all of these: compound 2.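

In this assay, hydrogen in place of methoxy on an aromatic carbon, para to a large group, gives a 1.7-fold higher number from compound 3 to compound 4 (0.24 log units; within the scatter). Hydrogen in place of trifluoromethyl on an aromatic carbon gives a 1.7-fold higher number from compound 1 to compound 4 (0.23 log units; within the scatter), so that group too stands apart from hydrogen by no more than the usual scatter. Hydrogen in place of hydroxy on an aromatic carbon gives an at least 1.0-fold lower number from compound 2 to compound 4 (0.01 log units; that floor lies within the scatter). The value of compound 2 is a limit and not a number, so the size of this last step is only a floor: the limit of > 100000 nM in this assay, at which 1 of the 4 values shown sits.

From the compounds shown here alone, whether any group on this ring can move the number beyond the scatter in this assay stays open. An amine or a carboxylic acid in place of the methoxy, para to a large group, would test this, as would a longer chain on the oxygen.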